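The compounds below may be only part of what the source reports. "The series", "measured", "known", "first", "only" and "open" are said of these compounds alone.

Values in a functional assay on SK-MEL-2 cells (Homo sapiens) for cytotoxicity (a higher number here means a weaker inhibitor, a lower number a stronger inhibitor), so far
compound 1 `Cc1ccc2c(N3CCN(C)CC3)nc(-c3ccccc3C)cc2c1` gives 3380 nM
compound 2 `CN1CCN(c2nc(-c3ccc(Cl)cc3)cc3c(N(C)C)cccc23)CC1` gives 4300 nM
compound 3 `COc1ccc(-c2cc3c(N(C)C)cccc3c(N3CCN(C)CC3)n2)cc1` gives 3980 nM

The three values lie within the scatter of each other. Compound 3 at 3980 nM has compound 2 as its nearest neighbour and compound 1 as its furthest, and neither gap leaves the scatter.

The open question is compound 4 `CN1CCN(c2nc(-c3ccccc3)cc3c(N(C)C)cccc23)CC1` and the change to it from compound 3 is hydrogen in place of methoxy on an aromatic carbon, 4-methoxyphenyl to phenyl, which counts out as hydrogen in place of methoxy on an aromatic carbon in full.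

Going by the values given here, one measured step bears on this place: methoxy in place of chloro on an aromatic carbon (see a 1.1-fold lower number from compound 2 to compound 3 (0.03 log units; within the scatter) for its size). That swap moved the value by no more than the scatter. Among the compounds with values here, it is only one step, and no compound measured so far carries hydrogen at this place. Within the data shown here, compound 1 differs from compound 3 in more than one place, so it offers no direct step.

In this assay no step beyond the scatter is therefore expected, in either direction. The estimated step is small (a 1.0-fold higher number from compound 3 to compound 4 (0.00 log units; within the scatter)) and within that expectation.

For compound 4 the expected value is 4000 nM with an estimated range from 2200 nM to 7200 nM as the working figure.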

Compound 4, half-maximal inhibitory concentration: 7080 nM
Estimate against measurement, compound 4: 1.8-fold (0.25 log units) below; the range from low to high includes it.
By their numbers in this assay, from the lowest: compounds 1, 3, 2 and 4 (each within the scatter of the next, the first and the last beyond it).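

In this assay hydrogen now stands at this place, on an aromatic carbon para to a large group, which gives the series its first reference without a substituent there: hydrogen in place of methoxy reads a 1.8-fold higher number from compound 3 to compound 4 (0.25 log units; within the scatter) and hydrogen in place of chloro reads a 1.6-fold higher number from compound 2 to compound 4 (0.22 log units; within the scatter) on the same shared core. With hydrogen, methoxy and chloro all represented, compound 2, compound 3 and compound 4 lie within the scatter of each other, so none of the swaps among these three groups at this place has yet produced a step beyond the scatter. No supporting measurement is available to explain these values.

Going by these compounds, whether a group of a different kind at this place, such as an amine, a carboxylic acid or a longer chain like butoxy, would give a step beyond the scatter stays open. Also open, on these data alone, is whether the same holds on the core of compound 1, which differs from the other compounds in more than one place and so offers no direct comparison.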